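A few compounds are considered here, and "the series" means these few. Any claim that something is new, unique, unknown or untested is made for them only; others in the source may bear on it.

Compound 1 `CC(C)(O)c1cncc(-n2ncc3ccccc32)c1` is the reference point of this small set. In an ADME assay on cells for inhibition of cytochrome P450 11B1, mitochondrial (Homo sapiens), read by HTRF, with stated times of 1 h and 3 h (on this read-out lower numbers stand for stronger inhibition and higher numbers for weaker inhibition), compound 1 gives 535 nM, the lowest of the three numbers recorded so far. Compound 2 `Cc1nn(-c2cncc(C(C)(C)O)c2)c2ccccc12` carries a methyl in place of hydrogen on an aromatic carbon and gives 779 nM; the step of a 1.5-fold higher number from compound 1 to compound 2 (0.16 log units; within the scatter) is within the scatter, so the two compounds cannot be told apart on this read-out. Compound 3 `CC(C)(O)c1cncc(-n2ncc3ccc(F)cc32)c1` carries a fluoro in place of hydrogen on an aromatic carbon and gives 1990 nM; the step of a 3.7-fold higher number from compound 1 to compound 3 (0.57 log units; beyond the scatter) is beyond the scatter and points toward weaker inhibition.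

Compound 4 `CC(C)(O)c1cncc(-n2ncc3cc(C(F)(F)F)ccc32)c1` differs from compound 1 by trifluoromethyl in place of hydrogen on an aromatic carbon. The two measured steps that bear on this change both replace a hydrogen on an aromatic carbon of the shared core with a small group, and neither of them lowered the number: one stayed within the scatter and the other rose modestly. A trifluoromethyl is larger than either a methyl or a fluoro, so the expectation is a step of similar or somewhat greater size in the same direction, that is toward weaker inhibition, as a 2.8-fold higher number from compound 1 to compound 4 (0.45 log units; beyond the scatter). Compound 4 is therefore expected to give about 1500 nM in this assay, with a likely range from 600 nM to 4000 nM.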

Compound 4, half-maximal inhibitory concentration: 1200 nM
Estimate against measurement, compound 4: 1.3-fold (0.10 log units) above, and the stated range covers the measured number.
By their numbers in this assay, from the lowest: compounds 1, 2, 4 and 3 (each within the scatter of the next, the first and the last beyond it).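

Replacing one hydrogen on this aromatic carbon with trifluoromethyl, a group of 4 heavy atoms, gives a 2.2-fold higher number from compound 1 to compound 4 (0.35 log units; beyond the scatter) in this assay. This is a modest step, so the number stays in the same general range even with a group this much larger than the hydrogen it replaces. Within the data shown here, compound 4 also joins compound 3 in having a step from compound 1 that lies beyond the scatter and points toward weaker inhibition, while compound 2 remains the one compound that cannot be told apart from compound 1. Nothing available explains why the trifluoromethyl change has this effect.

The compounds shown leave open whether an amine, a carboxylic acid or a longer chain on this same aromatic carbon would lower the number or raise it further. They also leave open how a methyl or a fluoro on this same carbon would compare with the trifluoromethyl, which would show whether the size of the step depends on the group or on where it sits.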